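The source may hold more compounds than are shown below. What is called first, only, known or untested is meant among the compounds shown, and "the series" means these compounds.

Measured so far in a functional assay on CHO-K1 cells for antagonist activity at C-X-C chemokine receptor type 3 (Homo sapiens), read by FLIPR, with a stated time of 10 min, in the presence of a further agent that is not named here; on this read-out higher numbers stand for weaker inhibition and lower numbers for stronger inhibition:
- compound 1 `C[C@@H]1CN(c2sc(C(F)(F)F)nc2-c2nc3ccccc3[nH]2)CCN1C(=O)Cn1cccn1` gives 13 nM
- compound 2 `Cc1nc(C)n(CC(=O)N2CCN(c3sc(C(F)(F)F)nc3-c3nc4c(C(F)(F)F)cccc4[nH]3)C[C@H]2C)n1` gives 6 nM

Of these two numbers, compound 1 stands at the higher one, and compound 2 sits at a lower number that lies beyond the usual scatter of this assay. Nothing links the two by a single change, so their values are simply taken as they stand.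

Compound 3 `C[C@@H]1CN(c2sc(C(F)(F)F)nc2-c2nc3ccccc3[nH]2)CCN1C(=O)CN1CCC(F)(F)CC1` is not yet measured. It differs from compound 1 in one place: 4,4-difluoropiperidin-1-yl in place of 1H-pyrazol-1-yl on a saturated chain carbon bound to a carbonyl carbon. The shared core of compound 1 and the rest of the molecule are kept unchanged.

Within the data shown here, no measured pair shows this change, so there is no step to borrow. Compound 1 is the only anchor, and the change is judged only on its own: a five-membered aromatic ring with two hetero atoms gives way to a six-membered non-aromatic ring with one hetero atom and two fluorines. For compound 3 the step of a 1.5-fold higher number from compound 1 to compound 3 (0.19 log units; within the scatter) is expected to be small, towards a somewhat higher number, though possibly not beyond the scatter. Compound 3 is therefore estimated at 20 nM, with a range from 6 nM to 70 nM.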

Compound 3, half-maximal inhibitory concentration: 15 nM
Compound 3: middle estimate off by 1.3-fold (0.12 log units), on the high side; the measured number falls inside the stated range.
By their numbers in this assay, from the lowest: compound 2; then compounds 1 and 3 (each within the scatter of the next).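

In this assay, among these compounds, putting 4,4-difluoropiperidin-1-yl in place of 1H-pyrazol-1-yl on a saturated chain carbon bound to a carbonyl carbon gives a 1.2-fold higher number from compound 1 to compound 3 (0.06 log units; within the scatter), the first step that can be read at this place. A five-membered aromatic ring with 2 hetero atoms thus gives way to a six-membered non-aromatic ring with 1 hetero atom, and the heavy atoms of the group go from 5 to 8, yet the two compounds cannot be told apart in this read-out, so for this pair an aromatic ring at this place is not required. Nothing given here accounts for this result.

From the compounds shown here alone, it remains open whether the piperidine ring without its two fluorines, a morpholine ring, an open-chain dimethylamino group or a carboxylic acid at this place would stay within the scatter of compound 1. Going by these compounds, it is also open whether the same exchange would give a similar step on the core of compound 2, which differs from compound 1 in more than one place and so offers no direct comparison.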